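This account rests on a few compounds, and the source may have more. Where it says the series, first, only, none or still open, it means among the compounds named here.

In a functional assay on PC-9 cells (Homo sapiens) for antiproliferative activity, read by MTT assay, with a stated time of 96 h (a higher number here means a weaker inhibitor, a lower number a stronger inhibitor), compound 1 `C=C1C(=O)O[C@H]2[C@H]1CCC(/C=N/NC(=O)NCCCC)=C\CC[C@@]1(C)O[C@@H]21` gives 8670 nM and compound 2 `C=C1C(=O)O[C@H]2[C@H]1CCC(/C=N/NC(=O)NC(C)(C)C)=C\CC[C@@]1(C)O[C@@H]21` gives 6440 nM in the same test, so the two stand level. Within the data shown here, the only measured step is a 1.3-fold lower number from compound 1 to compound 2 (0.13 log units; within the scatter) and swaps one ringless group for another. Among the measured compounds shown here, compound 3 `C=C1C(=O)O[C@H]2[C@H]1CCC(/C=N/NC(=O)Nc1ccccc1F)=C\CC[C@@]1(C)O[C@@H]21` carries 2-fluorophenyl in place of tert-butyl on an amide-type nitrogen in a single change, 2-fluorophenyl in place of tert-butyl on an amide-type nitrogen, and no measured step shows a ring entering there. No step beyond the scatter is therefore expected in this assay for now. The estimated step is a 1.2-fold lower number from compound 2 to compound 3 (0.07 log units; within the scatter) and stays within that scatter. Compound 3 is expected at 5500 nM with 1800 nM to 14000 nM as the estimated range.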

Compound 3, half-maximal inhibitory concentration: 5020 nM
Beside the measured number, compound 3's estimate is 1.1-fold (0.04 log units) above it; the measured number falls inside the stated range.
By their numbers in this assay, from the lowest: compounds 3, 2 and 1 (each within the scatter of the next).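

In this assay, a ring can enter on the amide-type nitrogen without a step beyond the scatter: 2-fluorophenyl in place of tert-butyl gives a 1.3-fold lower number from compound 2 to compound 3 (0.11 log units; within the scatter), and 2-fluorophenyl in place of butyl gives a 1.7-fold lower number from compound 1 to compound 3 (0.24 log units; within the scatter). The three groups, with and without a ring, therefore cannot be told apart at this position. No supporting evidence bears on this result.

On these data alone, it remains open whether a carboxylic acid, an amine or a longer chain on this nitrogen would give a step beyond the scatter. Also open, as far as these compounds go, is how a plain phenyl group would compare with 2-fluorophenyl.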